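Nitro for Fluoro in a Series Sitting at the Assay Limit

A few compounds are considered here, and "the series" means these few. Any claim that something is new, unique, unknown or untested is made for them only; others in the source may bear on it.

Measured in a functional assay on BT-549 cells (Homo sapiens) for inhibition, read by MTT assay, with a stated time of 48 h; a higher number here means a weaker inhibitor, a lower number a stronger inhibitor:
compound 1 `COc1cc(Cn2cc(COc3cccc(/C=C4\C(=O)Nc5ccccc54)c3)nn2)cc(OC)c1` — > 50000 nM
compound 2 `O=C1Nc2cc(Cl)ccc2/C1=C\c1cccc(OCc2cn(Cc3ccccc3)nn2)c1` — > 50000 nM
compound 3 `O=C1Nc2ccc(F)cc2/C1=C\c1cccc(OCc2cn(Cc3ccccc3)nn2)c1` — > 50000 nM

Each of these values is a limit of the assay, not a number. For compound 3 the result is such a limit, (the limit of > 50000 nM in this assay, at which 3 of the 3 values shown sit). On the numbers shown, nothing separates compound 3 from compound 1 or compound 2.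

Compound 4 `O=C1Nc2ccc([N+](=O)[O-])cc2/C1=C\c1cccc(OCc2cn(Cc3ccccc3)nn2)c1` differs from compound 3 in one place: nitro in place of fluoro on an aromatic carbon. For the measured compounds named here, no pair of measured compounds anchors the size of this change in this assay, so the direction is unknown from these data. Compound 4 is expected to remain near the limit, with a step that the limit leaves unreadable from compound 3 to compound 4 expected to fall within the scatter. The estimate for compound 4 is 60000 nM, ranging from 15000 nM to 250000 nM.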

Compound 4, half-maximal inhibitory concentration: > 50000 nM
Compound 4: no number, only a limit; the forecaster's own chance of this, stated with the estimate: 80%; the middle value lies beyond the limit too.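

No step can be read between compound 3 and compound 4: both results are limits of the assay, not numbers. The compounds shown leave open how strongly any of them inhibits in this assay, and whether nitro and fluoro differ there at all.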